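Trimming Two Methyls from the Most Potent Sulfonamide

This account rests on a few compounds, and the source may have more. Where it says the series, first, only, none or still open, it means among the compounds named here.

Three compounds share a core. Compound 1 `O=C1CS/C(=N/Nc2nncc3ccccc23)N1c1ccccc1` gives 63 nM in a functional assay on UO-31 cells (Homo sapiens) for antiproliferative activity, read by sulforhodamine B assay, with a stated time of 72 h (on this read-out higher numbers stand for weaker inhibition and lower numbers for stronger inhibition), compound 2 `NC(=S)NNc1nncc2ccccc12` gives 33 nM in this assay, and compound 3 `Cc1cc(C)nc(NS(=O)(=O)c2ccc(Nc3nncc4ccccc34)cc2)n1` gives 3.4 nM in this assay. Compound 3 therefore stands lowest of the three numbers, its gaps to compound 2 and to compound 1 both lying beyond the usual scatter. Compound 4 `O=S(=O)(Nc1ncccn1)c1ccc(Nc2nncc3ccccc23)cc1` differs from compound 3 in one place: pyrimidin-2-yl in place of 4,6-dimethylpyrimidin-2-yl on a sulfonamide nitrogen. No measured pair isolates this change, so its effect is not shown by the compounds in hand. The step expected in this assay is small, a 1.5-fold higher number from compound 3 to compound 4 (0.17 log units; within the scatter), within the scatter. Compound 4 is accordingly estimated at 5 nM in this assay, in the range 1.5 nM to 17 nM.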

Compound 4, half-maximal inhibitory concentration: 23 nM
The estimate for compound 4 lay 4.6-fold (0.66 log units) below the measured number; the measured number lies above the stated range.
By their numbers in this assay, from the lowest: compound 3; then compounds 4, 2 and 1 (each within the scatter of the next, the first and the last beyond it).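

On a sulfonamide nitrogen, trading 4,6-dimethylpyrimidin-2-yl for pyrimidin-2-yl gives a 6.8-fold higher number from compound 3 to compound 4 (0.83 log units; beyond the scatter) in this assay. Among the compounds shown here, this is the first measured pair to isolate a change at this position, and it shows that the methyl groups count here: keeping the pyrimidine ring alone does not keep the number of compound 3. Nothing measured here accounts for the step.

On these data alone, whether 4-methylpyrimidin-2-yl on the same nitrogen would fall nearer compound 3 or compound 4 stays open. So does the outcome with 4,6-dimethoxypyrimidin-2-yl or a plain phenyl there.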